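Swapping trifluoromethyl for pyrrolidinylcarbonyl on the aryl amine

The compounds below may be only part of what the source reports. "The series", "measured", "known", "first", "only" and "open" are said of these compounds alone.

Compound 1 `CN1CCN(Cc2ccc(NC(=O)Nc3ccc4ncnc(Nc5ccc(F)c(F)c5)c4c3)cc2)CC1` gives in a functional assay on A-431 cells (Homo sapiens) for antiproliferative activity, read by MTT assay, with a stated time of 72 h (a higher number here means a weaker inhibitor, a lower number a stronger inhibitor), only a limit, > 10000 nM.
Compound 2 `COc1ccc(Nc2ncnc3ccc(NC(=O)Nc4ccc(CN5CCN(C)CC5)cc4)cc23)cc1Cl` gives 2010 nM.
Compound 3 `CN1CCN(Cc2ccc(NC(=O)Nc3ccc4ncnc(Nc5cccc(C(F)(F)F)c5)c4c3)cc2)CC1` gives 2410 nM.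

Compound 3 and compound 2 sit together, since a 1.2-fold higher number from compound 2 to compound 3 (0.08 log units; within the scatter). The third value, that of compound 1, is a limit of the assay and not a number (the limit of > 10000 nM in this assay, at which 1 of the 3 values shown sits).

Compound 4 `CN1CCN(Cc2ccc(NC(=O)Nc3ccc4ncnc(Nc5cccc(C(=O)N6CCCC6)c5)c4c3)cc2)CC1` is the next member. It differs from compound 3 in one place: (pyrrolidin-1-yl)carbonyl in place of trifluoromethyl on an aromatic carbon. All three measured steps change the same aromatic group on the nitrogen of the shared core, so all bear on it. From compound 1 two changes gave clearly lower numbers, an at least 4.9-fold lower number from compound 1 to compound 2 (0.69 log units; beyond the scatter) and an at least 4.1-fold lower number from compound 1 to compound 3 (0.61 log units; beyond the scatter), while the swap between the two replacements gave a 1.2-fold higher number from compound 2 to compound 3 (0.08 log units; within the scatter). None of these steps brings in a carbonyl or a non-aromatic ring, so the direction for compound 4 is open. The expectation for compound 4 is a 1.2-fold higher number from compound 3 to compound 4 (0.10 log units; within the scatter), no step beyond the scatter. Compound 4 is therefore estimated at 3000 nM, within 800 nM to 12000 nM.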

Compound 4, half-maximal inhibitory concentration: > 10000 nM
Compound 4: no number, only a limit; the forecaster's own chance of this, stated with the estimate: 25%; middle value at least 3.3-fold (0.52 log units) away from the limit.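

The change from trifluoromethyl to (pyrrolidin-1-yl)carbonyl on this aromatic carbon gives an at least 4.1-fold higher number from compound 3 to compound 4 (0.61 log units; beyond the scatter), the only step shown toward a higher number that lies beyond the scatter. This shows that the number in this assay depends on what sits at this position, and that a group bringing a carbonyl and a five-membered non-aromatic ring goes with weaker inhibition than trifluoromethyl here. Compound 4 gives > 10000 nM, which is a limit of the assay and not a number, so the step has a lower bound but no known full size: the limit of > 10000 nM in this assay, at which 2 of the 4 values shown sit.

The compounds shown leave open whether the carbonyl, the ring or both account for this step. An open-chain dimethylamide or a carboxylic acid on this same aromatic carbon would help separate those parts.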